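The source may report more compounds than this note shows. Statements on the series, on what has been measured and on what is new or still open speak of the compounds shown alone.

Compound 3 `COc1ccc(-c2cc3cc(OC)ccc3nc2Nc2ccc(NC(=O)CN3CCCC3)cc2)cc1` gives 13100 nM in a functional assay on HUVEC cells (Homo sapiens) for antiproliferative activity, read by MTT assay, with a stated time of 48 h (on this read-out higher numbers stand for weaker inhibition and lower numbers for stronger inhibition), the second highest of the three numbers in hand. Its nearest neighbour, compound 2 `COc1ccc(-c2cc3cc(OC)ccc3nc2Nc2ccc(NC(=O)CN(C)C)cc2)cc1`, gives 22200 nM; compound 1 `COc1ccc(-c2cc3ccc(OC)cc3nc2Nc2ccc(NC(=O)CN3CCN(C)CC3)cc2)cc1` gives 7400 nM, and both of these lie within the scatter of compound 3. Compound 4 `COc1ccc(-c2cc3cc(OC)ccc3nc2Nc2ccc(NC(=O)CN3CCN(C)CC3)cc2)cc1` differs from compound 3 by 4-methylpiperazin-1-yl in place of pyrrolidin-1-yl on a saturated chain carbon bound to a carbonyl carbon. Within the data shown here, the only measured step that bears on this change is the amine swap a 1.7-fold lower number from compound 2 to compound 3 (0.23 log units; within the scatter), which stayed within the scatter. Compound 1 carries the same 4-methylpiperazin-1-yl group as compound 4 and differs elsewhere, with a value close to that of compound 3. Compound 4 is therefore expected to show a 1.4-fold lower number from compound 3 to compound 4 (0.14 log units; within the scatter) in this assay, a step within the scatter. The estimated value of compound 4 is 9500 nM, with a range from 4000 nM to 22000 nM.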

Compound 4, half-maximal inhibitory concentration: 7400 nM
For compound 4 the middle estimate is 1.3-fold (0.11 log units) above the measured one; the range from low to high includes it.
By their numbers in this assay, from the lowest: compounds 1, 4, 3 and 2 (each within the scatter of the next, the first and the last beyond it).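

In this assay, 4-methylpiperazin-1-yl in place of pyrrolidin-1-yl on a saturated chain carbon bound to a carbonyl carbon stays within the scatter (a 1.8-fold lower number from compound 3 to compound 4 (0.25 log units; within the scatter)), whereas the same group in place of dimethylamino goes beyond it, though only modestly (a 3.0-fold lower number from compound 2 to compound 4 (0.48 log units; beyond the scatter)). Among these compounds, this is the only amine change at this place that the scatter does not cover, and compound 3 cannot be separated from either compound 2 or compound 4. Nothing measured here explains this difference. From the compounds shown here alone, whether morpholin-4-yl or a primary amine at this place would fit these numbers remains open.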